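Swapping an Amine Ester for a Fluorophenyl Ester

This account rests on a few compounds, and the source may have more. Where it says the series, first, only, none or still open, it means among the compounds named here.

Three measured compounds share one core and differ only in the group attached to the ester carbonyl carbon. Compound 1 `C=C1C(=O)O[C@@H]2CC(C)=C([C@@H](C)CCCOC(C)=O)[C@@H](OC(=O)CN(CC)CC)[C@H]12` carries a (diethylamino)methyl group there; in a functional assay on SGC-7901 cells (Homo sapiens) for cytotoxicity, read by sulforhodamine B assay, with a stated time of 72 h (a higher number here means a weaker inhibitor, a lower number a stronger inhibitor), compound 1 gives 11600 nM. Compound 2 `C=C1C(=O)O[C@@H]2CC(C)=C([C@@H](C)CCCOC(C)=O)[C@@H](OC(=O)COc3cccc4[nH]nnc34)[C@H]12` gives 21100 nM, and compound 3 `C=C1C(=O)O[C@@H]2CC(C)=C([C@@H](C)CCCOC(C)=O)[C@@H](OC(=O)c3ccccc3F)[C@H]12` gives 19300 nM. Compound 1 has the lowest of the three numbers, but the other two sit close to it: a 1.7-fold higher number from compound 1 to compound 3 (0.22 log units; within the scatter) and a 1.8-fold higher number from compound 1 to compound 2 (0.26 log units; within the scatter), so none of the three can be called stronger or weaker than another.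

Compound 4 `C=C1C(=O)O[C@@H]2CC(C)=C([C@@H](C)CCCOC(C)=O)[C@@H](OC(=O)c3cccc(F)c3)[C@H]12` has not yet been measured. Compared with compound 1 it shows (3-fluorophenyl in place of (diethylamino)methyl on a carbonyl carbon). For the measured compounds named here, the step that bears most on this is the one to compound 3, which also replaces the (diethylamino)methyl group with a fluorophenyl group: a 1.7-fold higher number from compound 1 to compound 3 (0.22 log units; within the scatter). Compound 2 shows a larger aromatic replacement giving a similar outcome, a 1.8-fold higher number from compound 1 to compound 2 (0.26 log units; within the scatter). Accordingly the step to compound 4 is expected to be small, a 1.6-fold higher number from compound 1 to compound 4 (0.19 log units; within the scatter), nothing beyond the scatter. The estimate for compound 4 in this assay is 18000 nM, expected to fall between 9000 nM and 36000 nM.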

Compound 4, half-maximal inhibitory concentration: 12900 nM
Compound 4: the middle estimate sits 1.4-fold (0.14 log units) above what was measured; measured number inside the range.
By their numbers in this assay, from the lowest: compounds 1, 4, 3 and 2 (each within the scatter of the next).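

Changing where the fluorine sits on the ring, with 3-fluorophenyl in place of 2-fluorophenyl, does not move the result in this assay beyond the usual scatter (a 1.5-fold lower number from compound 3 to compound 4 (0.17 log units; within the scatter)). The second fluorophenyl ester also stays within the scatter of the amine ester (a 1.1-fold higher number from compound 1 to compound 4 (0.05 log units; within the scatter)) and of the larger group with two fused aromatic rings (a 1.6-fold lower number from compound 2 to compound 4 (0.21 log units; within the scatter)), so four quite different groups on this carbonyl carbon cannot be told apart here. No measurement is available that would explain this flat result.

These compounds leave open whether any group at this carbonyl carbon can shift the number beyond the scatter. A phenyl group without fluorine, a carboxylic acid or a longer chain could test that.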